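Swapping one bicyclic aromatic group for another on the urea

A few compounds are considered here, and "the series" means these few. Any claim that something is new, unique, unknown or untested is made for them only; others in the source may bear on it.

Compound 1 `CC1CCN(c2nc(C(F)(F)F)ccc2CNC(=O)Nc2ccc3cccnc3c2)CC1`: 7.1 nM
Compound 2 `CC1CCN(c2nc(C(F)(F)F)ccc2CNC(=O)Nc2cnc3ccccc3c2)CC1`: 9.5 nM
Compound 3 `CC1CCN(c2nc(C(F)(F)F)ccc2CNC(=O)Nc2ccc3cnncc3c2)CC1`: 8.9 nM

Three ureas built on the same core were tested in an assay on isolated protein for antagonist activity at transient receptor potential cation channel subfamily V member 1 (Homo sapiens), read by FLIPR; on this read-out higher numbers stand for weaker inhibition and lower numbers for stronger inhibition. Compound 2 gives 9.5 nM; the step of a 1.3-fold higher number from compound 1 to compound 2 (0.13 log units; within the scatter) and the step of a 1.1-fold lower number from compound 2 to compound 3 (0.03 log units; within the scatter) both stay within the scatter, as does a 1.3-fold higher number from compound 1 to compound 3 (0.10 log units; within the scatter). Compound 4 `CC1CCN(c2nc(C(F)(F)F)ccc2CNC(=O)Nc2cccc3nccnc23)CC1` differs from compound 2 by a single exchange: quinoxalin-5-yl in place of quinolin-3-yl on an amide-type nitrogen. Each of the three measured steps also swaps one bicyclic aromatic group for another on this nitrogen, and none of them shifts the number beyond the scatter. Compound 4 is therefore expected to show a 1.1-fold lower number from compound 2 to compound 4 (0.02 log units; within the scatter). The estimate for compound 4 in this assay is 9 nM, with a range from 3 nM to 30 nM.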

Compound 4, inhibition constant: 48.1 nM
Beside the measured number, compound 4's estimate is 5.3-fold (0.73 log units) below it; measured number above the stated range.
By their numbers in this assay, from the lowest: compounds 1, 3 and 2 (each within the scatter of the next); then compound 4.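

On this amide-type nitrogen, the choice of bicyclic aromatic group can matter: quinoxalin-5-yl gives weaker inhibition in all three comparisons (a 5.1-fold higher number from compound 2 to compound 4 (0.70 log units; beyond the scatter)) (a 5.4-fold higher number from compound 3 to compound 4 (0.73 log units; beyond the scatter)) (a 6.8-fold higher number from compound 1 to compound 4 (0.83 log units; beyond the scatter)). Compounds 3 and 4 carry groups with the same counts of atoms and the same ring types, so those counts alone do not set the number here. No supporting measurement accounts for this difference.

The compounds shown leave open whether quinolin-5-yl or quinoxalin-6-yl on this nitrogen would give numbers like those of compounds 1, 2 and 3 or like that of compound 4.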